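A Nitro Group Replaces Fluorine on the Chain

The source may report more compounds than this note shows. Statements on the series, on what has been measured and on what is new or still open speak of the compounds shown alone.

Compound 3 `COc1ccc(C(=O)/C(=C/c2ccccc2F)CCOC(C)=O)cc1` is recorded in a functional assay on MCF7 cells (Homo sapiens) for inhibition, read by XTT assay, with a stated time of 48 h (on this read-out lower numbers stand for stronger inhibition and higher numbers for weaker inhibition), only as a limit, > 100000 nM, so no number stands for it. That limit is the one at which one of the three values shown sits (the limit of > 100000 nM in this assay, at which 1 of the 3 values shown sits). Compound 4 `COc1ccc(C(=O)/C(=C/c2ccc([N+](=O)[O-])cc2)CCOC(C)=O)cc1` differs from it by 4-nitrophenyl in place of 2-fluorophenyl on a double-bonded chain carbon bound to a double-bonded chain carbon. Within the data shown here, the only measured step at that place runs through compounds carrying a different ester chain: compound 1 `COc1ccc(C(=O)/C(=C/C2CCCCC2)COC(=O)c2ccccc2)cc1` gives 13700 nM, and compound 2 `COc1ccc(C(=O)/C(=C/c2ccccc2Cl)COC(=O)c2ccccc2)cc1` gives 9000 nM. That comparison amounts to a 1.5-fold lower number from compound 1 to compound 2 (0.18 log units; within the scatter). It bears only loosely on the present change, and it stayed within the scatter, so a step of about a number no higher from compound 3 to compound 4 (the limit leaves the size open) is expected, none beyond the scatter. Compound 4 is therefore estimated at 100000 nM, between 30000 nM and 300000 nM, quite possibly again reported only as a limit.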

Compound 4, half-maximal inhibitory concentration: > 100000 nM
Compound 4 gave a limit, no number (the forecaster's own chance of this, stated with the estimate: 60%); the middle value lies on the limit itself.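

Among these compounds, compound 3 and compound 4 are both recorded only as limits, so no step between them can be read: the limit of > 100000 nM in this assay, at which 2 of the 4 values shown sit. Going by these compounds, what 4-nitrophenyl in place of 2-fluorophenyl does to the number stays open, since neither compound has one.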